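The source may hold more compounds than are shown below. What is called first, only, known or untested is meant among the compounds shown, and "the series" means these compounds.

Measured compounds:
compound 1, `C[C@H](NC(=O)c1c(Cc2ccc(F)cc2)sc2c1CCOC2)c1ccc(C(=O)NN)cc1`, 74.9 nM;
compound 2, `C[C@H](NC(=O)c1c(Cc2ccc(C(C)(C)C)cc2)sc2c1CCOC2)c1ccc(C(=O)O)cc1`, 9.5 nM.

Both numbers come from a functional assay on CHO/Galpha16 cells for antagonist activity at prostaglandin E2 receptor EP4 subtype (Homo sapiens), read by calcium flux, with a stated time of 15 min; a higher number here means a weaker inhibitor, a lower number a stronger inhibitor. Going by the values given here, compound 2 holds the lowest of the two numbers; the only neighbour is compound 1, whose number is higher by a gap beyond the scatter, so compound 2 is the stronger inhibitor of the pair. Among the compounds with values here, no step between compounds that differ in one place is available, so the two values show only that the pair differ, not which part of the molecule accounts for it.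

Compound 3, `C[C@H](NC(=O)c1c(C#Cc2ccc(=O)[nH]c2)sc2c1CCOC2)c1ccc(C(=O)O)cc1`, is not yet measured. It differs from compound 2 as follows: a group of 9 heavy atoms (7 carbon, 1 nitrogen, 1 oxygen; one six-membered aromatic ring with 1 hetero atom) in place of a group of 11 heavy atoms (11 carbon; one six-membered aromatic ring of carbon only), on an aromatic carbon. The change sits on an aromatic carbon of the five-membered aromatic ring with one sulfur, next to the ring sulfur. Within the data shown here, with no comparable step among the measured compounds, the direction is uncertain; the author expects the step of a 3.2-fold higher number from compound 2 to compound 3 (0.50 log units; beyond the scatter), a moderate weakening beyond the scatter. Compound 3 is accordingly estimated at 30 nM, in the range 6 nM to 200 nM.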

Compound 3, half-maximal inhibitory concentration: 642 nM
Compound 3: middle estimate off by 21-fold (1.33 log units), on the low side; measured number outside the range, above it.
By their numbers in this assay, from the lowest: compound 2; then compound 1; then compound 3.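

Going by these compounds alone, with the rest of the molecule held constant, putting the pyridone-bearing alkyne in place of the 4-(tert-butyl)benzyl group gives a 68-fold higher number from compound 2 to compound 3 (1.83 log units; beyond the scatter) in this assay, the first single-place step and a large one, showing that activity at this position, next to the ring sulfur, depends strongly on the group it carries. The step exchanges a carbon-only aromatic ring for one with a hetero atom, adds a triple bond and a double bond outside aromatic rings, and adds a hydrogen-bond donor and acceptor, so it cannot be assigned to any one of these. No measurement bears on the reason for the loss.

The compounds shown leave open how much of the step belongs to the triple bond and how much to the ring. A phenylethynyl group or a pyridone ring on a methylene link would separate the two.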